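The compounds below may be only part of what the source reports. "The series", "measured", "known", "first", "only" and "open" are said of these compounds alone.

Measured so far: compound 3 `C=CCn1c(=O)/c(=C\c2cccc(C)c2)[nH]c(=O)/c1=C\c1ccccc1OC` with 32800 nM; compound 2 `C=CCn1c(=O)/c(=C\c2ccccc2C(F)(F)F)[nH]c(=O)/c1=C\c1ccccc1OC` with 14500 nM; compound 1 `C=CCn1c(=O)/c(=C\c2cc(Br)ccc2F)[nH]c(=O)/c1=C\c1ccccc1OC` with "not active" (no number reported).

In a functional assay on NCI-H1975 cells (Homo sapiens) for cytotoxicity, read by CCK-8 assay, with a stated time of 72 h (a lower number here means a stronger inhibitor, a higher number a weaker inhibitor), compound 3 gives the highest of the two numbers reported, and its nearest neighbour is compound 2, from which the change is a 2.3-fold higher number from compound 2 to compound 3 (0.35 log units; beyond the scatter). Compound 1 returned no number in this assay at all. Compound 4 `C=CCn1c(=O)/c(=C\c2ccccc2F)[nH]c(=O)/c1=C\c1ccccc1OC` differs from compound 3 by 2-fluorophenyl in place of 3-methylphenyl on a double-bonded chain carbon bound to an aromatic carbon. For the measured compounds named here, only one measured step bears on this kind of exchange, the swap of one phenyl substituent for another on that same carbon, and it was modest: a 2.3-fold higher number from compound 2 to compound 3 (0.35 log units; beyond the scatter). Compound 4 is therefore expected to remain a weak inhibitor, and the step from compound 3 to compound 4 is estimated to be small, a 1.3-fold lower number from compound 3 to compound 4 (0.12 log units; within the scatter), in either direction no more than the scatter would cover. For compound 4 the estimate in this assay is 25000 nM, within a range from 8000 nM to 70000 nM, with a real chance that, like compound 1, it yields no number.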

Compound 4, half-maximal inhibitory concentration: 25100 nM
Compound 4: middle estimate off by 1.0-fold (0.00 log units), on the low side, within the range that was stated.
By their numbers in this assay, from the lowest: compounds 2, 4 and 3 (each within the scatter of the next, the first and the last beyond it).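

In this assay the exchange of 3-methylphenyl for 2-fluorophenyl on a double-bonded chain carbon bound to an aromatic carbon gives a 1.3-fold lower number from compound 3 to compound 4 (0.12 log units; within the scatter) and the exchange of trifluoromethyl for fluoro on an aromatic carbon gives a 1.7-fold higher number from compound 2 to compound 4 (0.24 log units; within the scatter) so neither change can be told apart from repeat measurement. Compound 4 thus lies within the scatter of both neighbours and bridges a gap that looked real when only compound 2 and compound 3 were known. Compound 4 also returns a number, whereas compound 1 gives "not active" (no number reported) as its result.

From the compounds shown here alone, whether an amine or a carboxylic acid on this aromatic ring would move the number beyond the scatter remains open. Nothing shown explains these numbers or the missing one of compound 1.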